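Methoxy on the Core Phenyl: Expectation for Compound 4

The source may hold more compounds than are shown below. What is called first, only, known or untested is meant among the compounds shown, and "the series" means these compounds.

Compound 1 `COc1cc(/C=C/C(=O)c2cccc(-n3cc(-c4ccccc4)[nH]c3=O)c2)ccc1O`: 1950 nM
Compound 2 `O=C(/C=C/c1cccc(O)c1)c1cccc(-n2cc(-c3ccccc3)[nH]c2=O)c1`: 2490 nM
Compound 3 `COc1cc(/C=C/C(=O)c2cccc(-n3cc(-c4ccccc4)[nH]c3=O)c2)cc(OC)c1OC`: 1400 nM

In a functional assay on NCI-H460 cells (Homo sapiens) for inhibition (on this read-out lower numbers stand for stronger inhibition of growth and higher numbers for weaker inhibition of growth), compound 1 stands second highest of the three numbers, with compound 2 nearest and compound 3 furthest, both within the scatter. Compound 4 `COc1ccc(-c2cn(-c3cccc(C(=O)/C=C/c4ccc(O)c(OC)c4)c3)c(=O)[nH]2)cc1` differs from compound 1 by methoxy in place of hydrogen on an aromatic carbon, which cut one bond further out reads phenyl to 4-methoxyphenyl. Within the data shown here, no measured step touches this phenyl; the only measured step, a 1.3-fold higher number from compound 1 to compound 2 (0.11 log units; within the scatter), alters the aryl on the chain and lies within the scatter. Among the measured compounds shown here, with no relevant precedent, the expected step of no change at the digits printed from compound 1 to compound 4 (within the scatter) is none beyond the scatter. Compound 4 is therefore estimated at 1950 nM, within 900 nM to 4200 nM.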

Compound 4, concentration for 50% growth inhibition: 3230 nM
Compound 4: middle estimate off by 1.7-fold (0.22 log units), on the low side, within the range that was stated.
By their numbers in this assay, from the lowest: compounds 3, 1, 2 and 4 (each within the scatter of the next, the first and the last beyond it).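

The phenyl of the shared core now has a reading of its own: in this assay, the change from phenyl to 4-methoxyphenyl gives a 1.7-fold higher number from compound 1 to compound 4 (0.22 log units; within the scatter) and so cannot be told apart from repeat measurements. At this place, para to a large group, the methoxy therefore leaves the growth inhibition without a clear shift. Nothing available explains the size of this step.

As far as these compounds go, whether an amine or a carboxylic acid at this place would also stay within the scatter remains open. So does whether the methoxy would behave alike with the chain aryl of compound 2 or compound 3.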